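Methyl on the Ring Nitrogen: Weighing a Small Change

A few compounds are considered here, and "the series" means these few. Any claim that something is new, unique, unknown or untested is made for them only; others in the source may bear on it.

Compound 1, `Cc1ccc2[nH]c(SCC(=O)N3CCC[C@H]3C(=O)Nc3ccccc3-n3cccc3)nc2c1`, gives 0.2 nM in an assay on CHO cells for displacement of a labelled ligand from Orexin receptor type 2 (Homo sapiens); a higher number here means a weaker inhibitor, a lower number a stronger inhibitor.
Compound 2, `Cn1c(SCC(=O)N2CCC[C@H]2C(=O)Nc2ccccc2-c2ccccc2)nc2ccccc21`, gives 0.2 nM in this assay.
Compound 3, `O=C(Nc1ccccc1)[C@@H]1CCCN1C(=O)CSc1nc2ccccc2[nH]1`, gives 560 nM in this assay.

Compound 1 and compound 2 stand level at the digits shown, within the usual scatter of this assay, and together they give the lowest two numbers of the three. Compound 3 gives a far higher number, well beyond the scatter, so it is the weakest inhibitor of the set.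

Compound 4, `Cc1ccc2c(c1)nc(SCC(=O)N1CCC[C@H]1C(=O)Nc1ccccc1-n1cccc1)n2C`, has not yet been measured. It differs from compound 1 in one place only: methyl in place of hydrogen on an aromatic nitrogen. Going by the values given here, no pair of measured compounds isolates this change. Compound 2 also carries a methyl on the ring nitrogen of its core and gives a number level with compound 1, but compound 2 differs from compound 1 in other places as well, so its value can only hint that the methyl is tolerated.

On that hint, no step beyond the scatter is expected in either direction. Compound 4 is expected to give 0.3 nM in this assay, with a range from 0.1 nM to 1.5 nM. The expected step of a 1.5-fold higher number from compound 1 to compound 4 (0.18 log units; within the scatter) stays within the scatter.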

Compound 4, inhibition constant: 0.09 nM
For compound 4 the middle estimate is 3.3-fold (0.52 log units) above the measured one; the measured number lies below the stated range.
By their numbers in this assay, from the lowest: compound 4; then compounds 1 and 2 (each within the scatter of the next); then compound 3.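

Going by these compounds alone, the pair of compound 1 and compound 4 is the first to isolate this change, which compound 2 could only hint at. In this assay, methyl in place of hydrogen on an aromatic nitrogen gives a 2.2-fold lower number from compound 1 to compound 4 (0.35 log units; beyond the scatter), so in this pair the hydrogen on that ring nitrogen is not needed for a very low number, and the added carbon costs nothing at this place. Nothing shown here explains why the number falls, so the step stands as an observation only.

From the compounds shown here alone, this reading rests on one pair, and it remains open whether the same methyl would move the number the same way on another compound that carries hydrogen on this nitrogen, such as compound 3, which gives 560 nM in this assay. Going by these compounds, it also remains open how far this position stretches: whether an ethyl, a longer chain, or a chain ending in an amine or a carboxylic acid on the same nitrogen would keep the number as low as the methyl does.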